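The compounds below may be only part of what the source reports. "The series", "measured", "known", "first", "only" and "open" are said of these compounds alone.

Two ureas of one shared core have been measured. Compound 1 `O=C(NCC1(c2ccccc2)CCCCC1)Nc1ccccc1` gives 2300 nM in an assay on microsomes from intestine for inhibition of acyl-CoA:cholesterol acyltransferase (Oryctolagus cuniculus); a lower number here means a stronger inhibitor, a higher number a weaker inhibitor. Compound 2 `O=C(NCC1(c2ccccc2)CCCCC1)Nc1cccc(Cl)c1Cl` gives 1300 nM in this assay; on paper its number is the smaller of the two, with compound 1 nearest, but the step of a 1.8-fold lower number from compound 1 to compound 2 (0.25 log units; within the scatter) lies within the scatter, so the pair is not separated. Compound 3 `O=C(NCC1(c2ccccc2)CCCCC1)Nc1cc(Cl)ccc1Cl` has not yet been measured; it differs from compound 2 in one place: 2,5-dichlorophenyl in place of 2,3-dichlorophenyl on an amide-type nitrogen. For the measured compounds named here, the only measured step that touches this part of the molecule is a 1.8-fold lower number from compound 1 to compound 2 (0.25 log units; within the scatter), which concerns 2,3-dichlorophenyl in place of phenyl, not one dichlorophenyl in place of another; no measured pair compares two dichlorophenyl groups. The expectation in this assay is therefore no step beyond the scatter. For compound 3 the expected step is a 1.2-fold higher number from compound 2 to compound 3 (0.06 log units; within the scatter). Compound 3 is estimated at 1500 nM, within 500 nM to 4500 nM.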

Compound 3, half-maximal inhibitory concentration: 2700 nM
Estimate against measurement, compound 3: 1.8-fold (0.26 log units) below; measured number inside the range.
By their numbers in this assay, from the lowest: compounds 2, 1 and 3 (each within the scatter of the next, the first and the last beyond it).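

Working notes: in this assay the exchange of 2,3-dichlorophenyl for 2,5-dichlorophenyl on the amide-type nitrogen gives a 2.1-fold higher number from compound 2 to compound 3 (0.32 log units; beyond the scatter) and is the first step at this position to lie beyond the scatter, though only modestly, so the arrangement of the same atoms on the ring can separate two compounds here. The step of a 1.2-fold higher number from compound 1 to compound 3 (0.07 log units; within the scatter) is within the scatter, so 2,5-dichlorophenyl is not separated from phenyl, and neither dichlorophenyl group has a step from phenyl beyond the scatter. No measurement available here bears on why the two dichlorophenyl groups differ.

Open, on these data alone, is how a single chlorine on the phenyl ring would compare with these groups. Also open, as far as these compounds go, is whether a methoxy group or a trifluoromethyl group at this position would give a step larger than those seen so far.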